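This account rests on a few compounds, and the source may have more. Where it says the series, first, only, none or still open, it means among the compounds named here.

Measured so far in a functional assay on HCT-116 cells (Homo sapiens) for inhibition, read by MTT assay, with a stated time of 2 days, tested at 10 uM; a higher number here means more inhibition of growth at the concentration tested, a lower number less inhibition of growth:

Compound 1 `CNC(=O)c1cc(Oc2ccc3nc(NC(=O)c4ccc(Cl)cc4)sc3c2)ccn1` gives 27.5%.
Compound 2 `CNC(=O)c1cc(Oc2ccc3nc(NC(=O)c4cccc(F)n4)sc3c2)ccn1` gives 10.8%.

Among the measured compounds shown here, compound 2 stands lowest of the two numbers in this assay; its nearest neighbour is compound 1, and the only step that has been measured, a number 16.7 percentage points lower from compound 1 to compound 2 (beyond the scatter), is a modest one. The next compound, compound 3 `CNC(=O)c1cc(Oc2ccc3nc(NC(=O)Nc4ccc(F)cc4)sc3c2)ccn1`, differs from compound 2 by (4-fluorophenyl)amino in place of 6-fluoropyridin-2-yl on a carbonyl carbon.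

For the measured compounds named here, only one measured step bears on this change, and it does so loosely: a number 16.7 percentage points lower from compound 1 to compound 2 (beyond the scatter) concerns the swap of one ring for another on the same carbonyl carbon, whereas the change to compound 3 also brings in an amino group with one hydrogen-bond donor. The measured step shows that the ring on that carbonyl carbon matters by a modest amount in this assay. On that basis a modest move upward in this assay is expected, though with wide uncertainty, so that the expected step is a number 9.2 percentage points higher from compound 2 to compound 3 (within the scatter). For compound 3 the expected value is 20%, within a range from 5% to 40%.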

Compound 3, percent growth inhibition at one concentration: 12.2%
Estimate against measurement, compound 3: 7.8 percentage points above; low and high end bracket the measured number.
By their numbers in this assay, from the lowest: compounds 2 and 3 (each within the scatter of the next); then compound 1.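

In this assay, (4-fluorophenyl)amino in place of 6-fluoropyridin-2-yl on a carbonyl carbon gives a number 1.4 percentage points higher from compound 2 to compound 3 (within the scatter), so at this position a carbon-only ring reached through an amino group, with its hydrogen-bond donor, reads no differently from the directly attached 6-fluoropyridin-2-yl. The same group in place of 4-chlorophenyl gives a number 15.3 percentage points lower from compound 1 to compound 3 (beyond the scatter), so among these three compounds only the one carrying 4-chlorophenyl stands apart, and compound 2 and compound 3 form a level pair despite their different groups. Nothing measured here explains why 4-chlorophenyl sets compound 1 apart from the other two.

The compounds shown leave open whether that separation follows the chlorine or the ring bonded directly to the carbonyl carbon, a question that (4-chlorophenyl)amino and 4-fluorophenyl at this place would help to settle. Also open, from the compounds shown here alone, is how this position responds to groups without an aromatic ring, such as a plain alkyl chain or a dimethylamino group.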